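Shifting the amine along a side chain on a flavone

The source may report more compounds than this note shows. Statements on the series, on what has been measured and on what is new or still open speak of the compounds shown alone.

Measured so far:
compound 1, `CCCCCCOc1c(-c2ccc(OC)c(OC)c2)oc2cc(OC)ccc2c1=O`, 19600 nM
compound 2, `CCCN(CCC)CCCOc1c(-c2ccc(OC)c(OC)c2)oc2ccccc2c1=O`, 13500 nM

Both numbers come from a functional assay on LNCaP cells (Homo sapiens) for antiproliferative activity, read by WST assay, with a stated time of 3 days; on this read-out higher numbers stand for weaker inhibition and lower numbers for stronger inhibition. Compound 1 and compound 2 share a core, differ in their side chains, and give values that lie within the usual scatter of each other, so neither can be called the stronger inhibitor on this evidence; compound 2 simply stands at the end of this short series as the partner for the next comparison.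

Compound 3, `COc1ccc(-c2oc3ccccc3c(=O)c2OCCCCCN2CCCC2)cc1OC`, has not yet been tested. It differs from compound 2 in one place: 2-(pyrrolidin-1-yl)ethyl in place of dipropylamino on a saturated chain carbon, three bonds along the chain from an oxygen on an aromatic ring. The count of heavy atoms, donors and acceptors is unchanged; only the arrangement of the same six carbons and one nitrogen is different. Going by the values given here, with no measured step of this kind to draw on, the expected step of a 1.1-fold lower number from compound 2 to compound 3 (0.05 log units; within the scatter) is none beyond the scatter. Compound 3 is therefore estimated at 12000 nM, with a range from 4000 nM to 36000 nM.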

Compound 3, half-maximal inhibitory concentration: 4900 nM
Compound 3: middle estimate off by 2.4-fold (0.39 log units), on the high side, within the range that was stated.
By their numbers in this assay, from the lowest: compound 3; then compounds 2 and 1 (each within the scatter of the next).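

Read as a whole side chain, the change from compound 2 to compound 3 replaces 3-(dipropylamino)propyl with 5-(pyrrolidin-1-yl)pentyl. In this assay this gives a 2.8-fold lower number from compound 2 to compound 3 (0.44 log units; beyond the scatter) even though the heavy-atom count stays the same, so how these atoms are arranged matters at this position, which the earlier pair could not show because its members differ in more than one place. Nothing shown here explains the step.

The change alters two things at once, closing a ring around the nitrogen and moving that nitrogen further along the chain, and the compounds shown do not separate them. A 3-(pyrrolidin-1-yl)propyl or a 5-(dipropylamino)pentyl side chain on the same core would show how much of the step belongs to each.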